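Trifluoromethyl on the Anilino Ring of Compound 1

The source may hold more compounds than are shown below. What is called first, only, known or untested is meant among the compounds shown, and "the series" means these compounds.

Compound 1 `COc1ccc(Cn2nc(-c3ccccc3)c3cc(C(=N)Nc4ccccc4)ncc32)cc1` is one of three measured compounds. In a functional assay on MDA-MB-231 cells (Homo sapiens) for cytotoxicity, read by MTT assay, with a stated time of 72 h (a higher number here means a weaker inhibitor, a lower number a stronger inhibitor), compound 1 gives 5400 nM, the second highest of the three numbers. Compound 2 `COc1ccc(Cn2nc(-c3ccccc3)c3cc(C(=N)Nc4ccccc4)nc(NC4CCCCC4)c32)cc1` carries a cyclohexylamino in place of hydrogen on an aromatic carbon of the shared core and gives 3400 nM; the step of a 1.6-fold lower number from compound 1 to compound 2 (0.20 log units; within the scatter) lies within the usual scatter. Compound 3 `N=C(Nc1ccccc1)c1cc2c(-c3ccccc3)n[nH]c2cn1` has hydrogen in place of 4-methoxybenzyl on an aromatic nitrogen and gives 11000 nM, so that a 2.0-fold higher number from compound 1 to compound 3 (0.31 log units; beyond the scatter) is a modest loss.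

Compound 4 `COc1ccc(Cn2nc(-c3ccccc3)c3cc(C(=N)Nc4cccc(C(F)(F)F)c4)ncc32)cc1` differs from compound 1 by trifluoromethyl in place of hydrogen on an aromatic carbon, a change on the anilino ring attached to the amidine. Neither measured step touches this ring: the step from compound 1 to compound 2 alters the core, the step from compound 1 to compound 3 alters the ring nitrogen, and both stayed small. They give no direct guide to the new change; the only observation is that single changes around compound 1 have moved this assay by little. The expected step for compound 4 is therefore small, a 1.2-fold lower number from compound 1 to compound 4 (0.08 log units; within the scatter), not beyond the scatter in either direction. Compound 4 is estimated at 4500 nM, with a range from 1500 nM to 13000 nM.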

Compound 4, half-maximal inhibitory concentration: > 50000 nM
Compound 4 gave a limit, no number; the forecaster's own chance of this, stated with the estimate: 5%; middle value at least 11-fold (1.04 log units) away from the limit.
By their numbers in this assay, from the lowest: compounds 2 and 1 (each within the scatter of the next); then compound 3. At a limit, above all of these: compound 4.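

The anilino ring attached to the amidine, which neither earlier step touched, proves far less tolerant in this assay than the places changed before: an at least 9.2-fold higher number from compound 1 to compound 4 (0.96 log units; beyond the scatter). The result for compound 4 is a limit and not a number: the limit of > 50000 nM in this assay, at which 1 of the 4 values shown sits. The earlier steps shown here, which put cyclohexylamino on the shared core and removed 4-methoxybenzyl from the aromatic nitrogen, suggested that single changes around compound 1 move this read-out little, but trifluoromethyl, with only 4 heavy atoms, on an aromatic carbon meta to a large group shows that this does not hold for every place on the molecule.

With a single substituted anilino ring among the compounds shown, it remains open whether the loss belongs to trifluoromethyl itself or would follow any group at this place, as a methyl, a chlorine atom or a methoxy group in the same place could show. The compounds shown also hold no measurement that explains the loss, and they do not tell whether the same change would act alike on the cyclohexylamino core of compound 2.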